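The source may hold more compounds than are shown below. What is called first, only, known or untested is meant among the compounds shown, and "the series" means these compounds.

Measured compounds:
Compound 1 `CN(C)CCCNc1nc(-c2ccc(NC(=O)Nc3ccc(F)cc3)cc2)nc2c(Cl)c(Cl)sc12` — 650 nM in a functional assay on NCI-H460 cells (Homo sapiens) for cytotoxicity, read by MTT assay, with a stated time of 72 h; on this read-out higher numbers stand for weaker inhibition and lower numbers for stronger inhibition
Compound 2 `Cc1ccc(NC(=O)Nc2ccc(-c3nc(NCCCN(C)C)c4sc(Cl)c(Cl)c4n3)cc2)cc1` — 1110 nM
Compound 3 `CN(C)CCNc1nc(-c2ccc(NC(=O)Nc3ccc(F)cc3)cc2)nc2c(Cl)c(Cl)sc12` — 590 nM

Compound 3 sits at the low end of these three numbers, yet neither compound 1 nor compound 2 is separated from it beyond the scatter, as a 1.1-fold lower number from compound 1 to compound 3 (0.04 log units; within the scatter) shows. Compound 4 `CN(C)CCNc1nc(-c2ccc(NC(=O)Nc3ccc(Cl)cc3Cl)cc2)nc2c(Cl)c(Cl)sc12` differs from compound 3 by 2,4-dichlorophenyl in place of 4-fluorophenyl on an amide-type nitrogen. Going by the values given here, the one measured step that touches this part of the molecule, a 1.7-fold higher number from compound 1 to compound 2 (0.23 log units; within the scatter), stayed within the scatter, so a swap of substituents on this aromatic ring has so far moved little. Among the compounds with values here, no measured step covers a second halogen on that ring. Compound 4 is therefore expected to give about 700 nM, within 300 nM to 1800 nM, which means a 1.2-fold higher number from compound 3 to compound 4 (0.07 log units; within the scatter) is expected.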

Compound 4, half-maximal inhibitory concentration: 1520 nM
Compound 4: middle estimate off by 2.2-fold (0.34 log units), on the low side, within the range that was stated.
By their numbers in this assay, from the lowest: compounds 3, 1, 2 and 4 (each within the scatter of the next, the first and the last beyond it).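

In this assay, the aromatic ring on the amide-type nitrogen proves able to move the number beyond the scatter: 2,4-dichlorophenyl in place of 4-fluorophenyl gives a 2.6-fold higher number from compound 3 to compound 4 (0.41 log units; beyond the scatter), whereas the earlier swap on this ring, a 1.7-fold higher number from compound 1 to compound 2 (0.23 log units; within the scatter), did not. Nothing at hand speaks to what lies behind this step.

The compounds shown do not separate the contributions of the two chlorines, which a 4-chlorophenyl group on the same nitrogen would address. Going by these compounds, whether the step carries over to the chain of compound 1 also remains open.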